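The source may report more compounds than this note shows. Statements on the series, on what has been measured and on what is new or still open speak of the compounds shown alone.

Compound 1 `CCOC(=O)Cn1c(=O)c(-c2ccc(OC)cc2)cc2c(OC)cc(OC)cc21`: 10000 nM
Compound 2 `CCN(CC)C(=O)Cn1c(=O)c(-c2ccc(OC)cc2)cc2c(OC)cc(OC)cc21`: 10000 nM
Compound 3 `COc1ccc(-c2cc3c(OC)cc(OC)cc3n(CCCC#N)c2=O)cc1`: 10000 nM

All three compounds were tested in a functional assay on A-427 cells (Homo sapiens) for cytotoxicity, read by colorimetric assay and MTT assay; a lower number here means a stronger inhibitor, a higher number a weaker inhibitor. Among them, compound 3 stands level with the other two, at 10000 nM.

The next compound, compound 4 `COc1ccc(-c2cc3c(OC)cc(OC)cc3n(CC(=O)OCc3ccccc3)c2=O)cc1`, keeps the shared core and changes only the side chain: benzyloxycarbonyl in place of 2-cyanoethyl on a saturated chain carbon bound to an aromatic nitrogen. Benzyloxycarbonyl thus takes the place of 2-cyanoethyl on a saturated chain carbon bound to an aromatic nitrogen.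

Within the data shown here, three measured steps bear on this change. Two altered the same place, no change at the digits printed from compound 1 to compound 3 (within the scatter) and no change at the digits printed from compound 2 to compound 3 (within the scatter), and the third changed the group on a carbonyl carbon, no change at the digits printed from compound 1 to compound 2 (within the scatter). None of them moved the value beyond the scatter. The closest comparison is compound 1 at 10000 nM, whose ethoxycarbonyl group resembles the entering benzyloxycarbonyl. Among the measured compounds shown here, no measured compound carries the aromatic ring that enters with it, so a larger step cannot be ruled out, and the data favour no direction.

The expected result is therefore no shift beyond the scatter, and the estimated step is no change at the digits printed from compound 3 to compound 4 (within the scatter). For compound 4 the estimated value is 10000 nM, with an expected range from 4000 nM to 15000 nM.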

Compound 4, half-maximal inhibitory concentration: 10000 nM
Estimate against measurement, compound 4: no gap at the digits printed; low and high end bracket the measured number.
By their numbers in this assay, from the lowest: compounds 1, 2, 3 and 4 (each within the scatter of the next).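

In this assay the benzyloxycarbonyl side chain gave no change at the digits printed from compound 3 to compound 4 (within the scatter) and so brought a six-membered aromatic ring of carbon only to this place, on a saturated chain carbon bound to an aromatic nitrogen, without a shift beyond the scatter. The ester comparisons extend this reading: benzyloxy in place of diethylamino on a carbonyl carbon gave no change at the digits printed from compound 2 to compound 4 (within the scatter) and phenyl in place of methyl on a saturated chain carbon bound to an oxygen next to a carbonyl group gave no change at the digits printed from compound 1 to compound 4 (within the scatter) in the same assay, so neither the amide nor the ethyl ester differs from the benzyl ester at the digits printed. Nothing measured here offers an explanation for these unchanged values.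

Since all four compounds share one value, the compounds shown do not reveal whether any side chain at this place can move the number beyond the scatter. On these data alone, what a free carboxylic acid, a primary amine or a longer chain ending in a phenyl ring would give on this saturated chain carbon remains open.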